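This account rests on a few compounds, and the source may have more. Where it says the series, first, only, none or still open, it means among the compounds named here.

Measured compounds in a functional assay on K562 cells (Homo sapiens) for inhibition, read by fluorescence, with a stated time of 72 h; a lower number here means a stronger inhibitor of growth, a higher number a weaker inhibitor of growth:
compound 1, `Cc1nc(C2CC2)cc2nn(-c3ccccc3)cc12`, gives 25900 nM.
compound 2, `Cc1nc(CCO)cc2nn(-c3ccccc3)cc12`, reaches only the limit of the assay, > 100000 nM.
compound 3, `OCCc1cc2nn(-c3ccccc3)cc2cn1`, likewise reaches only the limit of the assay, > 100000 nM.

Compound 2 therefore stands at a limit and not at a number, and it shares that limit with compound 3 (the limit of > 100000 nM in this assay, at which 2 of the 3 values shown sit). Going by the values given here, the one readable step leading into compound 2 is an at least 3.8-fold higher number from compound 1 to compound 2 (0.58 log units; beyond the scatter), a loss when the 2-hydroxyethyl group took the place of cyclopropyl on the core. The further step that the two limits leave unreadable from compound 2 to compound 3 is not readable, as both compounds sit at the limit.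

Compound 4, `Cc1nc(-c2ccccc2)cc2nn(-c3ccccc3)cc12`, differs from compound 2 by phenyl in place of 2-hydroxyethyl on an aromatic carbon. The step from compound 1 to compound 2 bears on this change: removing a ring from that carbon cost activity, and compound 4 puts a ring back at the same carbon. Compound 4 is therefore expected to move back toward a readable value, by roughly an at least 5.0-fold lower number from compound 2 to compound 4 (0.69 log units; beyond the scatter). Compound 4 is estimated at 20000 nM, with a range from 3000 nM to 100000 nM.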

Compound 4, concentration for 50% growth inhibition: 6300 nM
Compound 4: middle estimate off by 3.2-fold (0.50 log units), on the high side; the measured number falls inside the stated range.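

In this assay, phenyl on this aromatic carbon gives an at least 15-fold lower number from compound 2 to compound 4 (1.20 log units; beyond the scatter). Compound 2 holds only a limit of the assay, so that step is a minimum and its full size stays unknown: the limit of > 100000 nM in this assay, at which 2 of the 4 values shown sit.

Going by these compounds alone, what the earlier compounds did not show is that two ring groups at this carbon can differ, as phenyl in place of cyclopropyl gives a 4.1-fold lower number from compound 1 to compound 4 (0.61 log units; beyond the scatter), so a ring of any kind does not settle the value here.

The compounds shown leave open whether a pyridyl ring, a benzyl group or an amine on this carbon would follow phenyl or fall back toward compound 2. As far as these compounds go, what the methyl group contributes also stays open, as the step between compound 2 and compound 3 cannot be read.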